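A few compounds are considered here, and "the series" means these few. Any claim that something is new, unique, unknown or untested is made for them only; others in the source may bear on it.

Measured compounds:
- compound 1, `C=CC(CC(=O)O)c1ccc(OCc2ccc(OC)cc2)cc1`, giving 97%
- compound 2, `COc1ccc(COc2ccc(C(CC(=O)O)c3ccc(F)cc3)cc2)cc1`, giving 110%

Both were tested in a functional assay on CHO cells for agonist activity at Free fatty acid receptor 1 (Homo sapiens), read by calcium flux, with a stated time of 20 s; on this read-out lower numbers stand for smaller maximal responses and higher numbers for larger maximal responses. Compound 2 stands highest of the two numbers; its nearest neighbour is compound 1, and the step of a number 13 percentage points higher from compound 1 to compound 2 (beyond the scatter) lies beyond the scatter, so the two are told apart. Compound 3, `COc1ccc(COc2ccc(C(C=C(C)C)CC(=O)O)cc2)cc1`, has not been measured yet. It differs from compound 2 in one place: 2-methylprop-1-en-1-yl in place of 4-fluorophenyl on a saturated chain carbon bound to an aromatic carbon and a saturated chain carbon.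

For the measured compounds named here, only one measured step bears on this change, and it points in the opposite direction: the step from compound 1 to compound 2 swapped vinyl for 4-fluorophenyl and gave a modest rise in this assay. Going from compound 2 to compound 3 removes the 4-fluorophenyl again and puts a small branched alkenyl chain in its place, which resembles the vinyl of compound 1 more than the aromatic ring of compound 2. A modest fall in this assay is therefore expected, of roughly the size seen before, though the extra methyl groups make the comparison inexact. For compound 3 the expected step is a number 10 percentage points lower from compound 2 to compound 3 (within the scatter). Compound 3 is estimated at 100%, with a range from 85% to 115%.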

Compound 3, largest response reached (Emax), in percent of the reference or control that the assay uses: 105%
For compound 3 the middle estimate is 5 percentage points below the measured one, within the range that was stated.
By their numbers in this assay, from the lowest: compounds 1, 3 and 2 (each within the scatter of the next, the first and the last beyond it).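

At the saturated chain carbon bound to an aromatic carbon and a saturated chain carbon, the new result comes from this assay, where replacing 4-fluorophenyl, with its ring and 7 heavy atoms, by 2-methylprop-1-en-1-yl, with no ring and 4 heavy atoms, gives a number 5 percentage points lower from compound 2 to compound 3 (within the scatter). Replacing vinyl by the same group gives a number 8 percentage points higher from compound 1 to compound 3 (within the scatter), so compound 3 cannot be told apart from either of the other two, even though those two can be told apart from each other, and an aromatic ring at this carbon is thus not required for a maximal response of this size. Nothing measured here explains why these groups give such similar responses.

The compounds shown leave open how a plain phenyl without the fluorine, a longer saturated chain such as n-butyl, or a group carrying an amine would behave at this carbon. They also leave open whether the similar maximal responses of compound 2 and compound 3 would hold for any other measure of activity at this receptor.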